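The source may report more compounds than this note shows. Statements on the series, on what has been measured and on what is new or still open speak of the compounds shown alone.

Compound 1, `CCCCCCCCCCOP(=O)(O)OCCSC(=S)N1CCCC1`, carries a pyrrolidin-1-yl group on its thiocarbonyl carbon, and in a functional assay on PC-3 cells (Homo sapiens) for inhibition, read by MTT assay, with stated times of 18 h and 4 h (a higher number here means a weaker inhibitor, a lower number a stronger inhibitor), compound 1 gives 56100 nM. Compound 2, `CCCCCCCCCCOP(=O)(O)OCCSC(=S)N1CCN(C)CC1`, differs from it by 4-methylpiperazin-1-yl in place of pyrrolidin-1-yl on the thiocarbonyl carbon, and in this assay compound 2 gives 80000 nM; the step of a 1.4-fold higher number from compound 1 to compound 2 (0.15 log units; within the scatter) lies within the scatter, so the two compounds are read as equal. Compound 2 has the higher of the two numbers, but only by that margin. Compound 3, `CCCOP(=O)(O)OCCSC(=S)N1CCCCC1`, with a propyl chain, reaches only the limit of this assay, > 100000 nM. One of the values shown therefore sits at a limit (the limit of > 100000 nM in this assay, at which 1 of the 3 values shown sits).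

Compound 4, `CCCCCCCCOP(=O)(O)OCCSC(=S)N1CCN(C)CC1`, is compound 2 with a shorter chain: hydrogen in place of ethyl on a saturated chain carbon, eight bonds along the chain from an oxygen on an unsaturated carbon. Cut one bond further out, the same difference reads butyl to ethyl. No measured step touches this chain; the only step shown changes the ring on the thiocarbonyl carbon and stays within the scatter. The shortest chain shown, in compound 3, gives only a limit. Against that background the step of a 1.4-fold higher number from compound 2 to compound 4 (0.14 log units; within the scatter) is expected to be small, tending toward a higher number, and compound 4 is estimated at 110000 nM, within a range from 55000 nM to 220000 nM.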

Compound 4, half-maximal inhibitory concentration: > 100000 nM
Compound 4: a limit, no number (the forecaster's own chance of this, stated with the estimate: 50%); the middle value lies beyond the limit too.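

Hydrogen in place of ethyl on this saturated chain carbon, eight bonds along the chain from an oxygen on an unsaturated carbon, gives the first step at this position in this assay: an at least 1.2-fold higher number from compound 2 to compound 4 (0.09 log units; that floor lies within the scatter). Compound 4 gives a limit, > 100000 nM, and not a number, so the step has only a floor; that floor lies within the scatter, which means the step neither shows a real change at this position nor rules out a larger one. What the earlier compounds did not show is that the limit now applies to more than one compound, so the effect of this change cannot be sized: the limit of > 100000 nM in this assay, at which 2 of the 4 values shown sit.

The compounds shown leave open whether a longer chain at this position, such as one with a further butyl stretch added, would give a clearly lower number in this assay than compound 2 does. They also leave open what a hydroxyl group, an amine or a carboxylic acid at the end of the chain would do, and whether the ring on the thiocarbonyl carbon matters at any other chain length.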